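The source may report more compounds than this note shows. Statements on the series, on what has been measured and on what is new or still open speak of the compounds shown alone.

Two compounds have numbers so far in a physicochemical assay, with a stated time of 30 min (on this read-out higher numbers stand for weaker inhibition and lower numbers for stronger inhibition), as follows:

Compound 1 `COc1cc2c(cc1OC)C(=O)C(C(=O)Nc1ccccc1)C2` gives 61.3 ug/mL
Compound 2 `COc1ccc(NC(=O)C2Cc3cc(OC)c(OC)cc3C2=O)cc1` gives 49.5 ug/mL

Compound 2 stands level with compound 1 within the scatter. Compound 3 `COc1cc2c(cc1OC)C(=O)C(C(=O)Nc1ccc(F)cc1)C2` has fluoro in place of methoxy on an aromatic carbon of compound 2 (fluoro in place of methoxy on an aromatic carbon). Going by the values given here, the one measured step on that aromatic carbon, methoxy in place of hydrogen, is a 1.2-fold lower number from compound 1 to compound 2 (0.09 log units; within the scatter) and so no step beyond the scatter is expected in this assay for this change. The step expected is a 1.1-fold higher number from compound 2 to compound 3 (0.05 log units; within the scatter) in size. For compound 3 the expected value is 56 ug/mL with 30 ug/mL to 105 ug/mL as its estimated range.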

Compound 3, half-maximal inhibitory concentration: 55 ug/mL
The estimate for compound 3 lay 1.0-fold (0.01 log units) above the measured number; measured number inside the range.
By their numbers in this assay, from the lowest: compounds 2, 3 and 1 (each within the scatter of the next).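

Fluoro is a third group on this aromatic carbon, and in this assay there is a 1.1-fold higher number from compound 2 to compound 3 (0.05 log units; within the scatter) and a 1.1-fold lower number from compound 1 to compound 3 (0.05 log units; within the scatter). Hydrogen, fluoro and methoxy therefore read alike here, so none of these three swaps at this position separates the compounds. No evidence is available to explain this. Still open, from the compounds shown here alone, is whether a different kind of group on this carbon, such as an amine or a carboxylic acid, would shift the number beyond the scatter. Changes elsewhere on the shared core also remain open.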